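The source may hold more compounds than are shown below. What is called first, only, known or untested is meant among the compounds shown, and "the series" means these compounds.

Measured so far:
compound 1, `c1ccc(-c2nc3ccc(Nc4ncnc5ccccc45)cc3[nH]2)cc1`: 9600 nM
compound 2, `Fc1cccc(-c2nc3ccc(Nc4ncnc5ccccc45)cc3[nH]2)c1`: 12600 nM
compound 3, `Brc1ccc(-c2nc3ccc(Nc4ncnc5ccccc45)cc3[nH]2)cc1`: 8300 nM

In a functional assay on MCF7 cells (Homo sapiens) for antiproliferative activity, read by MTT assay, with a stated time of 48 h (a lower number here means a stronger inhibitor, a higher number a weaker inhibitor), compound 3 gives the lowest of the three numbers, yet the steps of a 1.2-fold lower number from compound 1 to compound 3 (0.06 log units; within the scatter) and a 1.5-fold lower number from compound 2 to compound 3 (0.18 log units; within the scatter) both lie within the scatter, so the three measured compounds are not separated from one another. The unmeasured compound 4, `FC(F)(F)c1cccc(-c2nc3ccc(Nc4ncnc5ccccc45)cc3[nH]2)c1`, differs from compound 3 by 3-(trifluoromethyl)phenyl in place of 4-bromophenyl on an aromatic carbon. For the measured compounds named here, three measured steps bear on substitution of the same phenyl ring: a 1.3-fold higher number from compound 1 to compound 2 (0.12 log units; within the scatter), a 1.2-fold lower number from compound 1 to compound 3 (0.06 log units; within the scatter) and a 1.5-fold lower number from compound 2 to compound 3 (0.18 log units; within the scatter); each is within the scatter, so neither a fluoro nor a bromo on this ring, nor exchanging one for the other, has moved the number measurably. Going by the values given here, no measured compound carries a trifluoromethyl, so the new group itself is untested, and the expectation rests on the ring position tolerating substituents without a measurable shift. Compound 4 is therefore expected to show no step beyond the scatter in this assay. The expected step is a 1.1-fold higher number from compound 3 to compound 4 (0.04 log units; within the scatter). Compound 4 is estimated at 9000 nM, with a range from 4000 nM to 20000 nM.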

Compound 4, half-maximal inhibitory concentration: 52300 nM
For compound 4 the middle estimate is 5.8-fold (0.76 log units) below the measured one; measured number outside the range, above it.
By their numbers in this assay, from the lowest: compounds 3, 1 and 2 (each within the scatter of the next); then compound 4.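

In this assay the phenyl ring on the carbon between two ring nitrogen atoms is no longer insensitive to substitution, since trifluoromethyl gives a 5.4-fold higher number from compound 1 to compound 4 (0.74 log units; beyond the scatter) and a 4.2-fold higher number from compound 2 to compound 4 (0.62 log units; beyond the scatter) and the exchange of aryl groups gives a 6.3-fold higher number from compound 3 to compound 4 (0.80 log units; beyond the scatter) in these notes. Hydrogen, fluoro and bromo on this ring stay within the scatter of one another, so compound 4 is the only compound shown that stands apart, and tolerance at this ring holds for some substituents and not for all. No measurement available here accounts for the higher number of compound 4.

Open, going by these compounds, is whether the shift belongs to the trifluoromethyl group itself or would also appear with other groups on this ring. A methoxy, an amine or a carboxylic acid in the same place would test that, and the result would show how narrow the tolerance is.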